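This account rests on a few compounds, and the source may have more. Where it says the series, first, only, none or still open, it means among the compounds named here.

Measured compounds in the series:

Compound 1, `COc1cc(C(=O)/C=C\Nc2ccc(-c3nc4cc(OC)c(OC)c(OC)c4s3)cc2C)cc([N+](=O)[O-])c1OC`: 17400 nM
Compound 2, `COc1cc(OC)c2sc(-c3ccc(N/C=C\C(=O)c4ccc(OC)c(O)c4)cc3)nc2c1`: 10600 nM
Compound 3, `COc1ccc(C(=O)/C=C\Nc2ccc(-c3nc4cc(OC)c(OC)c(OC)c4s3)cc2C)cc1[N+](=O)[O-]`: 9100 nM

All three numbers come from a functional assay on A549 cells (Homo sapiens) for antiproliferative activity, read by sulforhodamine B assay, with a stated time of 48 h; on this read-out lower numbers stand for stronger inhibition and higher numbers for weaker inhibition. The three values sit close together; the gaps among compound 1, compound 2 and compound 3 are all within the scatter of this assay, so no order can be read from them.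

One single-point change is measured directly. Between compound 3 and compound 1 the difference is methoxy in place of hydrogen on an aromatic carbon, and this gave a 1.9-fold higher number from compound 3 to compound 1 (0.28 log units; within the scatter). The change in question is the methoxy in place of hydrogen on an aromatic carbon.

Compound 4, `COc1ccc(C(=O)/C=C\Nc2ccc(-c3nc4cc(OC)c(OC)c(OC)c4s3)cc2)cc1O`, is not yet measured. It differs from compound 2 by methoxy in place of hydrogen on an aromatic carbon. This is the same kind of change as that from compound 3 to compound 1, but the surroundings differ: in compound 4 the new methoxy sits ortho to two methoxy groups, meta to a fused ring and para to a fused ring, in a ring that is part of a fused system of two rings, whereas in compound 1 it sits ortho to a methoxy group, meta to a large group and meta to a nitro group. The difference between the core of compound 2 and the core of compound 3 is not broken down here.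

For compound 4 a step of about a 1.1-fold higher number from compound 2 to compound 4 (0.05 log units; within the scatter) is expected in this assay, resting on the small step seen from compound 3 to compound 1 of a 1.9-fold higher number from compound 3 to compound 1 (0.28 log units; within the scatter) and on compound 2 giving 10600 nM. Compound 4 is therefore estimated at 12000 nM, with a likely range from 5500 nM to 26000 nM.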

Compound 4, half-maximal inhibitory concentration: 23000 nM
Beside the measured number, compound 4's estimate is 1.9-fold (0.28 log units) below it, and the stated range covers the measured number.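

In this assay, methoxy in place of hydrogen on an aromatic carbon gives a 2.2-fold higher number from compound 2 to compound 4 (0.34 log units; beyond the scatter), a modest loss of antiproliferative activity on this core. Set beside the earlier step, the change carries over from one core to the other at a size that cannot be told apart: the same change on two cores in this assay, a 1.9-fold higher number (0.28 log units; within the scatter) from compound 3 to compound 1 and a 2.2-fold higher number (0.34 log units; beyond the scatter) from compound 2 to compound 4, 1.1-fold (0.05 log units) apart, within the scatter of two such steps. Going by these compounds alone, this is a reading of only two pairs, with the new methoxy in different surroundings, in a ring that is part of a fused system of two rings in compound 4 and in a ring carrying a nitro group in compound 1, so it shows agreement between these two cases and neither a general rule for the series nor a cause for the loss.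

Still open, as far as these compounds go, is whether the same step would appear on a core carrying neither the nitro group of compound 1 nor the hydroxy group of compound 4. Also open, from the compounds shown here alone, is how other groups would behave at the aromatic carbon that takes the methoxy in compound 4, for example a fluorine, an ethoxy group, an amine or a carboxylic acid.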